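The source may report more compounds than this note shows. Statements on the series, on what has been measured and on what is new or still open speak of the compounds shown alone.

Compound 1 `COc1cc(-c2nn(-c3cccc(NC(=O)Nc4cc(C(F)(F)F)cc(C(F)(F)F)c4)c3)cc2-c2ccncc2)ccc1Cl` gives 851 nM in a functional assay on SK-MEL-28 cells (Homo sapiens) for inhibition, read by sulforhodamine B assay, with a stated time of 48 h; on this read-out higher numbers stand for weaker inhibition of growth and lower numbers for stronger inhibition of growth. Compound 2 `O=C(Nc1cccc(-n2cc(-c3ccncc3)c(-c3ccc(Cl)c(O)c3)n2)c1)Nc1ccc(Cl)c(Cl)c1` gives 1460 nM in this assay, and compound 1 stands alongside it, the two numbers lying within the scatter of each other. Compound 3 `COc1cc(-c2nn(-c3cccc(NC(=O)Nc4cccc(C(F)(F)F)c4)c3)cc2-c2ccncc2)ccc1Cl` differs from compound 1 by hydrogen in place of trifluoromethyl on an aromatic carbon. Among the compounds with values here, no measured pair shows this change, so its size is not known from the series. Compound 3 is expected to give 1500 nM in this assay, within a range of 500 nM to 4500 nM. The estimated step of a 1.8-fold higher number from compound 1 to compound 3 (0.25 log units; within the scatter) would be a modest weakening, about at the edge of the scatter.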

Compound 3, concentration for 50% growth inhibition: 1120 nM
For compound 3 the middle estimate is 1.3-fold (0.13 log units) above the measured one; low and high end bracket the measured number.
By their numbers in this assay, from the lowest: compounds 1, 3 and 2 (each within the scatter of the next).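

With hydrogen in place of trifluoromethyl on this aromatic carbon, the first pair differing in one place gives a 1.3-fold higher number from compound 1 to compound 3 (0.12 log units; within the scatter) in this assay and so gives the series its first direct reading at this position. For this pair, the second trifluoromethyl group is not required for a value in this range. No measurement at hand bears on a cause for this result.

Still open, going by these compounds, is whether an amine or a carboxylic acid at this position would also stay within the scatter. On these data alone, the effect of replacing the remaining trifluoromethyl group is also open.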